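Swapping a pyridine substituent on a thiazole acetic acid

A few compounds are considered here, and "the series" means these few. Any claim that something is new, unique, unknown or untested is made for them only; others in the source may bear on it.

Two compounds have been characterised in an in vitro functional assay on HEK285-7 cells for antagonist activity at prostaglandin D2 receptor 2 (Homo sapiens), read by BRET and beta-arrestin recruitment; a lower number here means a smaller maximal response, a higher number a larger maximal response. Compound 1, `O=C(O)Cc1sc(C(c2ccc(F)cc2)c2ccc(F)cc2)nc1-c1ccnc(N2CCCC2)c1`, gives 80% in this assay, the higher of the two numbers. Compound 2, `O=C(O)Cc1sc(CS(=O)(=O)c2ccc(Cl)cc2)nc1-c1ccc(Cl)cc1`, gives 30% in this assay, a lower number, and the gap between the two is beyond the usual scatter. The two structures differ in several places at once, so the comparison says only what their two values show.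

Compound 3, `Nc1cc(-c2nc(C(c3ccc(F)cc3)c3ccc(F)cc3)sc2CC(=O)O)cc(F)n1`, has not yet been measured. It follows from compound 1 by a single change: 2-amino-6-fluoropyridin-4-yl in place of 2-(pyrrolidin-1-yl)pyridin-4-yl on an aromatic carbon. The change sits on an aromatic carbon of the five-membered ring of the shared core, next to the ring nitrogen and next to the ring atom that bears the carboxymethyl group, while the bis(4-fluorophenyl)methyl group and the carboxymethyl group are kept.

Without a measured single-point step in this series, the expected step of a number 10 percentage points lower from compound 1 to compound 3 (within the scatter) is small and, if anything, downward, not clearly beyond the scatter. On that basis compound 3 is estimated at 70% in this assay, with a plausible range from 45% to 95%.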

Compound 3, largest response reached (reported as efficacy), in percent of the reference or control that the assay uses: 30%
Estimate against measurement, compound 3: 40 percentage points above, outside the stated range (below it).
By their numbers in this assay, from the lowest: compounds 2 and 3 (each within the scatter of the next); then compound 1.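

In this assay, among these compounds, the step of a number 50 percentage points lower from compound 1 to compound 3 (beyond the scatter) is the first single change measured, and it shows that the group on this aromatic carbon, next to the ring nitrogen and next to the ring atom that bears the carboxymethyl group, can by itself change the maximal response. The shared core, the bis(4-fluorophenyl)methyl group and the carboxymethyl group are all kept, so the step belongs to the exchange of 2-(pyrrolidin-1-yl)pyridin-4-yl for 2-amino-6-fluoropyridin-4-yl. That exchange removes the five-membered non-aromatic ring and brings in an amine and a fluorine together, so this one step cannot be divided among those parts.

The compounds shown leave open whether a pyridin-4-yl carrying only the amine or only the fluorine, or one carrying a piperidine in place of the pyrrolidine, would give a response nearer that of compound 1 or that of compound 3. No measurement shown here explains the size of this step.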